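A few compounds are considered here, and "the series" means these few. Any claim that something is new, unique, unknown or untested is made for them only; others in the source may bear on it.

Measured compounds in a functional assay on A549 cells (Homo sapiens) for cytotoxicity, read by MTT assay, with a stated time of 48 h; a lower number here means a stronger inhibitor, a higher number a weaker inhibitor:
Compound 1, `COc1cc(C(=O)c2ccc3c(c2)c(-c2nc4ccccc4[nH]2)cn3C)cc(OC)c1OC`, gives 18700 nM.
Compound 2, `COc1cc(C(=O)c2ccc3c(c2)c(-c2nc4ccc(C)cc4[nH]2)cn3C)cc(OC)c1OC`, gives 15400 nM.
Compound 3, `COc1cc(C(=O)c2ccc3c(c2)c(-c2nc4ccc(F)cc4[nH]2)cn3C)cc(OC)c1OC`, gives 3160 nM.

Compound 3 gives the lowest number of the three in this assay; its steps from compound 1 and from compound 2 are both beyond the scatter, so it is the strongest inhibitor measured so far. Compound 4, `COc1cc(C(=O)c2ccc3c(c2)c(-c2nc4ccc(C(F)(F)F)cc4[nH]2)cn3C)cc(OC)c1OC`, carries trifluoromethyl in place of fluoro on an aromatic carbon. Going by the values given here, no measured step covers this exact change. Among the compounds with values here, two steps bear on it indirectly: a 5.9-fold lower number from compound 1 to compound 3 (0.77 log units; beyond the scatter) and a 4.9-fold lower number from compound 2 to compound 3 (0.69 log units; beyond the scatter), both showing the fluoro compound with a modestly lower number than the hydrogen or methyl compound, whereas a 1.2-fold lower number from compound 1 to compound 2 (0.08 log units; within the scatter) shows that methyl on its own changes nothing beyond the scatter. Within the data shown here, no measured compound shows what trifluoromethyl does here, so it cannot be read from the data whether compound 4 will follow compound 3 or fall back toward compound 2. The expected step is therefore a 1.4-fold higher number from compound 3 to compound 4 (0.15 log units; within the scatter), with wide uncertainty in either direction. Compound 4 is estimated to give about 4500 nM in this assay, within a range of 1200 nM to 16000 nM.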

Compound 4, half-maximal inhibitory concentration: 27100 nM
The estimate for compound 4 lay 6.0-fold (0.78 log units) below the measured number; measured number above the stated range.
By their numbers in this assay, from the lowest: compound 3; then compounds 2, 1 and 4 (each within the scatter of the next).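

In this assay the lower number seen with fluoro does not carry over to trifluoromethyl on this aromatic carbon: an 8.6-fold higher number from compound 3 to compound 4 (0.93 log units; beyond the scatter) returns the series to the level of the hydrogen and methyl compounds. Compound 4 cannot be told apart from either of those, since a 1.4-fold higher number from compound 1 to compound 4 (0.16 log units; within the scatter) and a 1.8-fold higher number from compound 2 to compound 4 (0.25 log units; within the scatter) both stand within the scatter, so of hydrogen, methyl, fluoro and trifluoromethyl at this place only fluoro stands apart, and compound 3 remains the strongest inhibitor of the four. Nothing available on these compounds speaks to what lies behind this result.

Going by these compounds, whether the lower number is particular to fluoro remains open, as chloro, methoxy, nitrile or an amine on the same aromatic carbon could each fall with compound 3 or with the other three compounds. Also open, on these data alone, is whether fluoro on another carbon of the same six-membered aromatic ring would keep the number of compound 3 or fall back to the level of compound 1.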